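The source may hold more compounds than are shown below. What is called first, only, known or untested is meant among the compounds shown, and "the series" means these compounds.

The measured compounds, all tested in an assay on HEK293 cells for displacement of a labelled ligand from metabotropic glutamate receptor 5 (Rattus norvegicus); on this read-out lower numbers stand for stronger inhibition and higher numbers for weaker inhibition:
Compound 1 `O=C(Nc1cc(-c2ccccc2)nn1-c1ccccc1)c1cccc([N+](=O)[O-])c1` gives 2220 nM.
Compound 2 `COc1ccc(C(=O)Nc2cc(-c3ccccc3)nn2-c2ccccc2)cc1` gives 420 nM.
Compound 3 `COc1cc(OC)cc(C(=O)Nc2cc(-c3ccccc3)nn2-c2ccccc2)c1` reaches only the limit of this assay, > 10000 nM.

Compound 3 therefore stands at the weak end of the three: its number is a limit rather than a value, and it sits at the limit of > 10000 nM in this assay, at which 1 of the 3 values shown sits. Both steps leading to it were unfavourable: an at least 4.5-fold higher number from compound 1 to compound 3 (0.65 log units; beyond the scatter) and an at least 23-fold higher number from compound 2 to compound 3 (1.37 log units; beyond the scatter). Compound 4 `O=C(Nc1cc(-c2ccccc2)nn1-c1ccccc1)c1ccncc1` is the next member; the change from compound 3 is pyridin-4-yl in place of 3,5-dimethoxyphenyl on a carbonyl carbon. Among the measured compounds shown here, no measured step bears directly on a pyridin-4-yl on the carbonyl carbon; the steps that involve compound 3 show only that leaving the 3,5-dimethoxyphenyl is where the gains lay, and that compound 1 and compound 2 gave numbers well inside the range of the assay. Since compound 3 is known only as a limit, the size of the step to compound 4 is open at its starting end; the expectation is a return into the measurable range, an at least 5.0-fold lower number from compound 3 to compound 4 (0.69 log units; beyond the scatter). Compound 4 is accordingly estimated at 2000 nM, with a likely range from 400 nM to 10000 nM.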

Compound 4, inhibition constant: > 10000 nM
Compound 4 ended at the assay's limit; the forecaster's own chance of this, stated with the estimate: 20%; middle value at least 5.0-fold (0.69 log units) away from the limit.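

Compound 4 joins compound 3 at the ceiling of this assay, and its number is likewise a limit: (the limit of > 10000 nM in this assay, at which 2 of the 4 values shown sit). On this carbonyl carbon, the pyridin-4-yl therefore falls clearly behind both groups that gave readable numbers, with an at least 23-fold higher number from compound 2 to compound 4 (1.37 log units; beyond the scatter) and an at least 4.5-fold higher number from compound 1 to compound 4 (0.65 log units; beyond the scatter) in the comparison, so a six-membered aromatic ring here does not by itself keep the number inside the assay's range. With limits at both ends, the step between compound 3 and compound 4 cannot be read, and the two cannot be placed in order.

From the compounds shown here alone, it remains open whether a plain phenyl or a pyridin-3-yl on the same carbonyl carbon would return to the measurable range. Also open, going by these compounds, is how far beyond the limit compound 3 and compound 4 actually lie.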